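A few compounds are considered here, and "the series" means these few. Any claim that something is new, unique, unknown or untested is made for them only; others in the source may bear on it.

Working notes on the series. The read-out throughout is a functional assay on the whole organism (Pleural cavity) for inhibition, with Rattus norvegicus as the target, at a dose of 25 mg/kg; a higher number here means more inhibition at the dose given (going by the name of the read-out), a lower number less inhibition. Compound 1 `CC1(C)C(=O)N(Cc2ccccc2)c2ncccc21` carries a benzyl group on the amide-type nitrogen in the ring, and in this assay compound 1 gives 12%. Compound 2 `CC(C)N1C(=O)C(C)(C)c2cccnc21` carries an isopropyl group on that nitrogen, and in this assay compound 2 gives 34%. Among the measured compounds shown here, of the two numbers measured so far, compound 2 stands highest, and the gap down to compound 1 lies beyond the usual scatter of this assay. For the measured compounds named here, no two measured compounds differ in a single place, so no step of one change has yet been measured, and the two readings say nothing directly about what a smaller alkyl group at this nitrogen does.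

Compound 3 `CN1C(=O)C(C)(C)c2cccnc21` is the next compound to be measured. It differs from compound 2 in one place: methyl in place of isopropyl on an amide-type nitrogen in a ring. Nothing measured isolates this change, so the expectation rests on compound 2 alone. The step of a number 8 percentage points lower from compound 2 to compound 3 (within the scatter) is expected to be a modest lowering, within or at the edge of the scatter. For compound 3 the expected value is therefore 26%, with a range from 8% to 44%.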

Compound 3, a percentage reported as inhibition, in the whole organism at one dose (the size of the read-out at that dose, not a potency): 69%
Estimate against measurement, compound 3: 43 percentage points below; the measured number lies above the stated range.
By their numbers in this assay, from the lowest: compound 1; then compound 2; then compound 3.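

At the amide-type nitrogen in the ring, this assay now gives two single changes, both ending at methyl: methyl in place of isopropyl gives a number 35 percentage points higher from compound 2 to compound 3 (beyond the scatter), and hydrogen in place of phenyl on the saturated chain carbon bound to that nitrogen gives a number 57 percentage points higher from compound 1 to compound 3 (beyond the scatter). This position is therefore not indifferent to its substituent, since each change moves the reading beyond the scatter with the rest of the structure held constant, and the methyl group of compound 3 carries the highest number of the three. Nothing at hand explains the size of these steps.

The compounds shown leave open what the amide hydrogen, an ethyl group or a longer chain at this nitrogen would do, and whether an amine or a carboxylic acid on such a chain would keep the reading of compound 3. From the compounds shown here alone, all three readings come from a single dose in this assay, and how compound 3 behaves at other doses remains open.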